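Sulfonyl substituent variation in a prostaglandin D2 receptor 2 series

A few compounds are considered here, and "the series" means these few. Any claim that something is new, unique, unknown or untested is made for them only; others in the source may bear on it.

Measured compounds:
compound 1 `COCCN(C)S(=O)(=O)c1ccc(C)c(C#Cc2cc(Cl)ccc2OCC(=O)O)c1`: 4.1 nM
compound 2 `Cc1ccc(S(=O)(=O)Cc2ccccc2)cc1C#Cc1cc(Cl)ccc1OCC(=O)O`: 5 nM
compound 3 `Cc1ccc(S(=O)(=O)N(C)C)cc1C#Cc1cc(Cl)ccc1OCC(=O)O`: 5 nM

In an assay on CHO cells for displacement of a labelled ligand from prostaglandin D2 receptor 2 (Homo sapiens), read by scintillation counting (a lower number here means a stronger inhibitor, a higher number a weaker inhibitor), compound 3 sits level with compound 2, and the step between the other two is a 1.2-fold higher number from compound 1 to compound 3 (0.09 log units; within the scatter). Compound 4 `CCN(CC)S(=O)(=O)c1ccc(C)c(C#Cc2cc(Cl)ccc2OCC(=O)O)c1` differs from compound 3 by diethylamino in place of dimethylamino on a sulfonyl sulfur.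

Among the compounds with values here, two measured steps touch the same sulfonyl sulfur: no change at the digits printed from compound 2 to compound 3 (within the scatter) and a 1.2-fold higher number from compound 1 to compound 2 (0.09 log units; within the scatter). Both swaps of the group on that sulfur left the number within the scatter. By that pattern, the step to diethylamino is expected to be no change at the digits printed from compound 3 to compound 4 (within the scatter), with no direction beyond the scatter.

Compound 4 is therefore estimated at 5 nM in this assay, within 2.5 nM to 10 nM.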

Compound 4, inhibition constant: 3.4 nM
The estimate for compound 4 lay 1.5-fold (0.17 log units) above the measured number; measured number inside the range.
By their numbers in this assay, from the lowest: compounds 4, 1, 2 and 3 (each within the scatter of the next).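

Going from dimethylamino to diethylamino on the sulfonyl sulfur gives a 1.5-fold lower number from compound 3 to compound 4 (0.17 log units; within the scatter) in this assay, so the added carbons of diethylamino move the number no further than the scatter. The steps of a 1.5-fold lower number from compound 2 to compound 4 (0.17 log units; within the scatter) and a 1.2-fold lower number from compound 1 to compound 4 (0.08 log units; within the scatter) are also within the scatter, so all four groups on this sulfur now read alike, with no order among them. Nothing available explains this flat reading.

As far as these compounds go, whether it holds for a piperidine, a primary amine or a carboxylic acid on the same sulfur stays open.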